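Solubility notes: compound 4 follows the carbamoyl route

The compounds below may be only part of what the source reports. "The series", "measured", "known", "first", "only" and "open" are said of these compounds alone.

Three members of the series have been measured in a physicochemical assay for solubility, read by HPLC, with a stated time of 24 h; on this read-out lower numbers stand for lower solubility and higher numbers for higher solubility. Compound 1 `O=C1CNC(=O)N1C[C@H]1CN(c2ccc(-n3cc(-c4ccccn4)cn3)c(F)c2)C(=O)O1` gives 1630000 nM. Compound 2 `O=C1O[C@@H](Cn2ccnc2)CN1c1ccc(-n2cc(-c3ccccn3)cn2)c(F)c1` gives 12300 nM, and compound 3 `O=C1O[C@@H](CSc2cccs2)CN1c1ccc(-n2cc(-c3ccccn3)cn2)c(F)c1` gives 8500 nM. Compound 3 thus holds the lowest of the three numbers, though its gap to compound 2 lies within the scatter; only its gap to compound 1 is a real one, as the step of a 190-fold lower number from compound 1 to compound 3 (2.28 log units; beyond the scatter) shows. The parallel step a 130-fold lower number from compound 1 to compound 2 (2.12 log units; beyond the scatter) points the same way.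

Compound 4 `CNC(=O)[C@H]1CN(c2ccc(-n3cc(-c4ccccn4)cn3)c(F)c2)C(=O)O1` has not yet been measured. The change from compound 3 is methylcarbamoyl in place of ((thiophen-2-yl)sulfanyl)methyl on a saturated ring carbon. Among the measured compounds shown here, no measured step alters the same place, but the step of a 190-fold lower number from compound 1 to compound 3 (2.28 log units; beyond the scatter) is the nearest guide: it shows that removing the ((thiophen-2-yl)sulfanyl)methyl side and putting back a smaller group with a hydrogen-bond donor can move this assay by a very large amount. The step of a 1.4-fold lower number from compound 2 to compound 3 (0.16 log units; within the scatter) adds nothing beyond the scatter. A large rise is therefore expected for compound 4, estimated as a 47-fold higher number from compound 3 to compound 4 (1.67 log units; beyond the scatter), though likely short of compound 1 because the entering methylcarbamoyl is smaller than the group of compound 1 and the step of a 190-fold lower number from compound 1 to compound 3 (2.28 log units; beyond the scatter) was measured with a different entering group. The estimate for compound 4 is 400000 nM, with a range from 80000 nM to 1600000 nM.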

Compound 4, solubility: 26200 nM
Beside the measured number, compound 4's estimate is 15-fold (1.18 log units) above it; measured number below the stated range.
By their numbers in this assay, from the lowest: compounds 3 and 2 (each within the scatter of the next); then compound 4; then compound 1.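

In this assay, methylcarbamoyl on the saturated ring carbon next to the ring oxygen stands only modestly clear of the two lowest members, with a 3.1-fold higher number from compound 3 to compound 4 (0.49 log units; beyond the scatter) and a 2.1-fold higher number from compound 2 to compound 4 (0.33 log units; beyond the scatter) on the same read-out. A group with a hydrogen-bond donor and no ring therefore does not by itself bring the number close to that of compound 1, with a 62-fold lower number from compound 1 to compound 4 (1.79 log units; beyond the scatter) still leaving a large gap, so among the groups shown only (2,5-dioxoimidazolidin-1-yl)methyl gives a number of that order. No measurement at hand accounts for these gaps.

The three other groups reach the ring carbon through a saturated chain carbon, whereas methylcarbamoyl sits on it directly, so the compounds shown do not separate the amide from that chain carbon; a longer chain such as (methylcarbamoyl)methyl would address this. Also open, going by these compounds, is how a charged or ionisable group at this place, such as an aminomethyl or a carboxylic acid, would compare with compound 1 and compound 4 on this read-out.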